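Whole-organism inhibition series: cyclopentyl to dimethylaminoethyl swap

This account rests on a few compounds, and the source may have more. Where it says the series, first, only, none or still open, it means among the compounds named here.

Measured so far:
compound 1 `c1nc(Nc2nncc3cncn23)n[nH]1`, 46000 nM
compound 2 `c1ncn2c(NC3CCCC3)nncc12`, > 48000 nM

In a functional assay for inhibition, with Homo sapiens as the target (a lower number here means a stronger inhibitor, a higher number a weaker inhibitor), compound 1 gives 46000 nM. For compound 2 the assay returned only a limit, > 48000 nM, so its true value is not a number. The step of an at least 1.0-fold higher number from compound 1 to compound 2 (0.01 log units; that floor lies within the scatter) is therefore bounded by the limit of > 48000 nM in this assay, at which 1 of the 2 values shown sits, and tells little. Compound 3 `CN(C)CCNc1nncc2cncn12` carries the change (2-(dimethylamino)ethyl in place of cyclopentyl on a nitrogen on an aromatic ring). Among the compounds with values here, no measured step bears directly on it; the only neighbouring step sits at the limit. A weak result is expected for compound 3 in this assay, estimated at 48000 nM with a range from 15000 nM to 150000 nM, a step of a number no higher from compound 2 to compound 3 (the limit leaves the size open) that may again end as a limit.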

Compound 3, half-maximal inhibitory concentration: > 48000 nM
Compound 3: a limit, no number; the forecaster's own chance of this, stated with the estimate: 65%; the middle value sits exactly at the limit.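

In this assay compound 3 gives only a limit, > 48000 nM, so 2-(dimethylamino)ethyl on a nitrogen on an aromatic ring yields no number, as with cyclopentyl. Set against 1H-1,2,4-triazol-3-yl, the change gives an at least 1.0-fold higher number from compound 1 to compound 3 (0.01 log units; that floor lies within the scatter). The step from compound 2 to compound 3 cannot be read, and this position gives no ranking of the open chain and the carbon ring: the limit of > 48000 nM in this assay, at which 2 of the 3 values shown sit.

From the compounds shown here alone, whether a carboxylic acid or a longer chain ending in a primary amine at this nitrogen would give a number rather than a limit stays open.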